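The source may hold more compounds than are shown below. What is called first, only, known or untested is meant among the compounds shown, and "the series" means these compounds.

Two compounds set the frame. Compound 1 `CC(=O)Nc1ccc(S(=O)(=O)Oc2ccccc2I)cc1` and compound 2 `CC(C)C(=O)Nc1ccc(S(=O)(=O)Oc2ccccc2C(C)C)cc1` were both tested in a functional assay on HT-1080 cells (Homo sapiens) for antiproliferative activity, read by sulforhodamine B assay, with a stated time of 48 h; on this read-out higher numbers stand for weaker inhibition and lower numbers for stronger inhibition. Compound 1 gives 17000 nM, while compound 2 gives 4900 nM, the lower of the two numbers, and the gap between them lies beyond the usual scatter. Compound 3 `CC(C)C(=O)Nc1ccc(S(=O)(=O)Oc2ccccc2I)cc1` carries iodo in place of isopropyl on an aromatic carbon. Among the measured compounds shown here, no step between measured compounds that differ in one place is known, so the size of this step is uncertain; a modest move toward weaker inhibition is expected because compound 1, which also carries iodo, gives 17000 nM. Compound 3 is therefore expected to give about 8000 nM, within 3000 nM to 25000 nM, an expected step of a 1.6-fold higher number from compound 2 to compound 3 (0.21 log units; within the scatter).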

Compound 3, half-maximal inhibitory concentration: 3300 nM
For compound 3 the middle estimate is 2.4-fold (0.38 log units) above the measured one, and the stated range covers the measured number.
By their numbers in this assay, from the lowest: compounds 3 and 2 (each within the scatter of the next); then compound 1.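

In this assay iodo in place of isopropyl on the aromatic carbon, ortho to a large group, gives a 1.5-fold lower number from compound 2 to compound 3 (0.17 log units; within the scatter) and so leaves the two groups indistinguishable at this position. Isopropyl in place of methyl on the carbonyl carbon gives a 5.2-fold lower number from compound 1 to compound 3 (0.71 log units; beyond the scatter) and is the first step in one place to lie beyond the scatter, so among these compounds only that carbonyl-carbon change separates the numbers. Nothing at hand explains either step. From the compounds shown here alone, whether a longer chain on the carbonyl carbon, or an amine on the aromatic carbon, would give a lower number stays open.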